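The compounds below may be only part of what the source reports. "The series", "measured", "known", "first", "only" and "open" are said of these compounds alone.

Among the compounds with values here, only two compounds have numbers so far in a functional assay on HL-60 cells (Homo sapiens) for cytotoxicity, read by MTT assay, with a stated time of 72 h; on this read-out lower numbers stand for stronger inhibition and higher numbers for weaker inhibition. Compound 1 `O=C(Nc1nnc(-c2cccc(O)c2O)s1)c1ccc(Cl)cc1` gives 9600 nM, and compound 2 `O=C(Nc1nnc(-c2ccc(O)c(O)c2)s1)c1ccc(Cl)cc1` gives 14700 nM. Within the data shown here, these two values lie within the usual scatter of each other, so compound 1 cannot be ranked against the only other compound measured.

The next compound, compound 3 `Cc1ccc(C(=O)Nc2nnc(-c3cccc(O)c3O)s2)cc1`, keeps the core of compound 1 and differs in one place: methyl in place of chloro on an aromatic carbon. This is methyl in place of chloro on an aromatic carbon, para to a large group, turning the 4-chlorophenyl into a 4-methylphenyl. Among the measured compounds shown here, no measured pair shows what such an exchange does in this assay, so the data give no direct precedent and any expectation stays loose. No step beyond the scatter is expected, and the direction is uncertain, with a slightly higher number only marginally favoured. The estimated change is a 1.3-fold higher number from compound 1 to compound 3 (0.10 log units; within the scatter), which is expected to stay small. For compound 3 the expected value is 12000 nM, with an estimated range from 5000 nM to 30000 nM.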

Compound 3, half-maximal inhibitory concentration: 10600 nM
The estimate for compound 3 lay 1.1-fold (0.05 log units) above the measured number, and the stated range covers the measured number.
By their numbers in this assay, from the lowest: compounds 1, 3 and 2 (each within the scatter of the next).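

In this assay, exchanging chloro for methyl, which turns the 4-chlorophenyl into a 4-methylphenyl, gives a 1.1-fold higher number from compound 1 to compound 3 (0.04 log units; within the scatter). This is the only pair shown that differs in one place, and it gives the first direct reading at this aromatic carbon, para to a large group: with the rest of compound 1 kept, the two groups cannot be told apart by this read-out. Within the data shown here, the result therefore shows only that this single exchange leaves the number within the usual scatter, and no accompanying measurement bears on why the two groups read alike.

As far as these compounds go, one pair says little about the position as a whole, so it remains open whether a group of another kind in the same place, such as an amine, a carboxylic acid or a longer chain like butyl, would shift the number beyond the scatter. From the compounds shown here alone, it also remains open whether the exchange of chloro for methyl would read the same on the core of compound 2, and whether it would hold on any cell line other than this one.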